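Compound 3 to compound 4: one more fluoro

The compounds below may be only part of what the source reports. "The series", "measured", "known", "first", "only" and "open" are said of these compounds alone.

Three amides on a shared core have been read in an ADME assay on LLC-MK2 cells (Macaca mulatta) for cytotoxicity, read by spectrophotometry and crystal violet staining, with a stated time of 4 days; a higher number here means that more compound is tolerated, a lower number that less compound is tolerated: compound 1 `CC(C)n1ncc2c(C(=O)Nc3ccc(F)cc3)cc(-c3cccs3)nc21`, compound 2 `CC(C)n1ncc2c(C(=O)Nc3cccc(F)c3)cc(-c3cccs3)nc21` and compound 3 `CC(C)n1ncc2c(C(=O)Nc3ccc(F)cc3F)cc(-c3cccs3)nc21`. Compound 1 gives > 200000 nM, a limit of the assay and not a number. Compound 2 gives > 200000 nM, again a limit. Compound 3 gives > 200000 nM, also only a limit. Compound 3 thus has no number of its own, and the whole measured set stands at the limit of > 200000 nM in this assay, at which 3 of the 3 values shown sit.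

Compound 4 `CC(C)n1ncc2c(C(=O)Nc3c(F)cc(F)cc3F)cc(-c3cccs3)nc21` differs from compound 3 by one change: fluoro in place of hydrogen on an aromatic carbon. In words, this is fluoro in place of hydrogen on an aromatic carbon, taking 2,4-difluorophenyl to 2,4,6-trifluorophenyl. The nearest measured precedent, the same replacement, is a step that the two limits leave unreadable from compound 1 to compound 3. The two other measured steps are a step that the two limits leave unreadable from compound 1 to compound 2 and a step that the two limits leave unreadable from compound 2 to compound 3. None of the three yields a size, and none of the three fluoro patterns has given a number.

No step beyond the scatter is therefore expected in this assay, and no direction can be assigned. The expected change is a number no higher from compound 3 to compound 4 (the limit leaves the size open), and another limit is the likeliest report. In this assay the estimate for compound 4 is 200000 nM, with an expected range of 110000 nM to 350000 nM.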

Compound 4, half-maximal cytotoxic concentration: > 200000 nM
Compound 4: a limit, no number; the forecaster's own chance of this, stated with the estimate: 85%; the middle value sits exactly at the limit.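

In this assay compound 4 gives > 200000 nM, a limit of the assay and not a number. Among the compounds shown here, no step from compound 1, compound 2 or compound 3 to compound 4 can be read, and the set now stands at one value: the limit of > 200000 nM in this assay, at which 4 of the 4 values shown sit. The compounds shown leave open whether these fluoro patterns differ at all in half-maximal cytotoxic concentration, and what number any of them would give.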